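A few compounds are considered here, and "the series" means these few. Any claim that something is new, unique, unknown or untested is made for them only; others in the source may bear on it.

Notes on the series. The shared core of compound 1 `CNc1ncccc1C(=O)N/N=C/c1ccccc1` carries a phenyl on the carbon with a double bond to nitrogen; in a functional assay on the whole organism (strain Wistar) for inhibition, with Rattus norvegicus as the target, read by paw edema, with a stated time of 1 h, at a dose of 10 mg/kg by the intraperitoneal route (a lower number here means less inhibition, a higher number more inhibition at the dose given (going by the name of the read-out)), compound 1 gives 67.6%. Compound 2 `CNc1ncccc1C(=O)N/N=C/c1cccnc1` differs in having pyridin-3-yl at that position, and in this assay compound 2 gives 61.1%. The change from compound 1 to compound 2 gives a number 6.5 percentage points lower from compound 1 to compound 2 (within the scatter), so the two measured values cannot be told apart. Compound 2 thus stands alongside compound 1 as one of two numbers that lie within the scatter of one another; no other comparison is available.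

Compound 3 `CNc1ncccc1C(=O)N/N=C/c1ccncc1` is not yet measured. Compared with compound 2 it differs as follows: pyridin-4-yl in place of pyridin-3-yl on a carbon with a double bond to nitrogen. Going by the values given here, the only measured step that bears on this position is that from compound 1 to compound 2, which moved the read-out by a number 6.5 percentage points lower from compound 1 to compound 2 (within the scatter), a shift inside the scatter. Nothing measured points to a shift beyond the scatter for a further rearrangement of the same ring, so the step from compound 2 to compound 3 is expected to be a number 0.1 percentage points lower from compound 2 to compound 3 (within the scatter). For compound 3 in this assay the estimated value is 61%, in the range 47% to 75%.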

Compound 3, a percentage reported as inhibition, in the whole organism at one dose (the size of the read-out at that dose, not a potency): 80.4%
Beside the measured number, compound 3's estimate is 19.4 percentage points below it; the measured number lies above the stated range.
By their numbers in this assay, from the lowest: compounds 2 and 1 (each within the scatter of the next); then compound 3.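

At this position the identity of the ring alone does not settle the read-out; the place of its nitrogen also matters. In this assay, pyridin-4-yl in place of pyridin-3-yl on the carbon with a double bond to nitrogen gives a number 19.3 percentage points higher from compound 2 to compound 3 (beyond the scatter), although the two groups have the same atoms and the same counts under the comparison, so the change is one of connection only. Pyridin-4-yl in place of phenyl gives a number 12.8 percentage points higher from compound 1 to compound 3 (beyond the scatter), which places compound 3 highest of the three, whereas compound 1 and compound 2 remain within the scatter of each other, and no measurement available offers an explanation for these steps.

Three aryl groups at a single dose and a single time give no trend, and the read-out at that dose says nothing about potency or about how long the inhibition lasts. Open too, going by these compounds, is whether pyridin-2-yl, or a phenyl or pyridin-4-yl carrying an amine or a carboxylic acid, would keep, raise or lower the read-out at this place on the shared core.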